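The source may report more compounds than this note shows. Statements on the series, on what has been measured and on what is new or still open speak of the compounds shown alone.

Measured so far in an ADME assay (liver) for metabolic stability, with Liver microsome (Rattus norvegicus) as the target, using microsomes and NADPH, with a stated time of 30 min, tested at 1 uM; on this read-out lower numbers stand for slow clearance and higher numbers for fast clearance:
- compound 1 `Nc1ccc(S(=O)(=O)N2CCN(c3ncc(C(O)(C(F)(F)F)C(F)(F)F)cc3C#CCCO)CC2)cn1`: 68 mL.min-1.g-1
- compound 2 `CS(=O)(=O)Nc1cccc(-c2cc(C(O)(C(F)(F)F)C(F)(F)F)cnc2N2CCN(S(=O)(=O)c3ccc(N)nc3)CC2)c1`: 81 mL.min-1.g-1

On these two numbers, compound 2 at 81 mL.min-1.g-1 cannot be told apart from compound 1. The next structure is compound 3 `CS(=O)(=O)c1ccc(-c2cc(C(O)(C(F)(F)F)C(F)(F)F)cnc2N2CCN(S(=O)(=O)c3ccc(N)nc3)CC2)cc1`, which makes one change to compound 2: 4-(methylsulfonyl)phenyl in place of 3-(methanesulfonamido)phenyl on an aromatic carbon. Here, 4-(methylsulfonyl)phenyl takes the place of 3-(methanesulfonamido)phenyl on an aromatic carbon.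

Among the measured compounds shown here, only one measured step bears on this, and it concerns the same carbon. Putting 3-(methanesulfonamido)phenyl in place of 4-hydroxybut-1-yn-1-yl gave a 1.2-fold higher number from compound 1 to compound 2 (0.08 log units; within the scatter). For the measured compounds named here, that is a single small step, and no measured compound yet carries 4-(methylsulfonyl)phenyl, so the evidence is thin. On that evidence, no shift beyond the scatter is expected in this assay, in either direction, and the expected step is a 1.1-fold lower number from compound 2 to compound 3 (0.03 log units; within the scatter). The estimated value for compound 3 is 75 mL.min-1.g-1, with an expected range from 40 mL.min-1.g-1 to 140 mL.min-1.g-1.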

Compound 3, intrinsic clearance in microsomes: 103 mL.min-1.g-1
Beside the measured number, compound 3's estimate is 1.4-fold (0.14 log units) below it; the range from low to high includes it.
By their numbers in this assay, from the lowest: compounds 1, 2 and 3 (each within the scatter of the next).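

In this assay, putting 4-(methylsulfonyl)phenyl in place of 3-(methanesulfonamido)phenyl gives a 1.3-fold higher number from compound 2 to compound 3 (0.10 log units; within the scatter) and so does not clearly change the read-out, even though the entering group has 0 hydrogen-bond donors and the leaving group has 1. Set against the 4-hydroxybut-1-yn-1-yl group, the same entering group gives a 1.5-fold higher number from compound 1 to compound 3 (0.18 log units; within the scatter) and so extends the earlier finding: a chain and two differently substituted phenyl groups on this aromatic carbon cannot be told apart. No measurement available here explains why these steps are small.

On these data alone, it remains open whether a group of another kind on this carbon, such as a simple amine or a carboxylic acid, would move the number beyond the scatter. These compounds also leave open whether changes elsewhere on the shared core would matter more.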